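From compound 2 to compound 4 in the uterus binding assay

This account rests on a few compounds, and the source may have more. Where it says the series, first, only, none or still open, it means among the compounds named here.

Compound 1 `CCCCOC(=O)NS(=O)(=O)c1sc(CC(C)C)cc1-c1ccc(CN2C(=O)CN(C)C2=O)cc1`: 68.6 nM
Compound 2 `CCCCOC(=O)NS(=O)(=O)c1sc(CC(C)C)cc1-c1ccc(CN2CCN(C)C2=O)cc1`: 16.5 nM
Compound 3 `CCCCOC(=O)NS(=O)(=O)c1sc(CC(C)C)cc1-c1ccc(Cc2nnc(C(F)(F)F)o2)cc1`: 328 nM

In a binding assay on membranes from uterus for displacement of a labelled ligand from Angiotensin type II receptor (Sus scrofa), with a stated time of 1.5 h (a higher number here means a weaker inhibitor, a lower number a stronger inhibitor), compound 2 gives the lowest of the three numbers; its nearest neighbour is compound 1 a 4.2-fold lower number from compound 1 to compound 2 (0.62 log units; beyond the scatter), and compound 3 stands furthest away a 20-fold higher number from compound 2 to compound 3 (1.30 log units; beyond the scatter). Compound 4 `CCCCOC(=O)NS(=O)(=O)c1sc(CC(C)C)cc1-c1ccc(C(=O)c2nccs2)cc1` has not yet been measured. It differs from compound 2 in one place: (1,3-thiazol-2-yl)carbonyl in place of (3-methyl-2-oxoimidazolidin-1-yl)methyl on an aromatic carbon.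

Among the compounds with values here, two measured steps bear on this. The step from compound 1 to compound 3 a 4.8-fold higher number from compound 1 to compound 3 (0.68 log units; beyond the scatter) and the step from compound 2 to compound 3 a 20-fold higher number from compound 2 to compound 3 (1.30 log units; beyond the scatter) both swap a saturated five-membered ring for an aromatic heterocycle at the same place, and both raise the number. Compound 4 makes a swap of the same kind, though the linker is a carbonyl rather than a methylene, so a higher number beyond the scatter is expected, with the step from compound 2 a 12-fold higher number from compound 2 to compound 4 (1.08 log units; beyond the scatter). For compound 4 the estimate in this assay is 200 nM, between 60 nM and 700 nM.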

Compound 4, inhibition constant: 18.6 nM
Compound 4: middle estimate off by 11-fold (1.03 log units), on the high side, and the stated range ends above it.
By their numbers in this assay, from the lowest: compounds 2 and 4 (each within the scatter of the next); then compound 1; then compound 3.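

In this assay the result shows that an aromatic five-membered ring on a carbonyl is accommodated at this position: a 1.1-fold higher number from compound 2 to compound 4 (0.05 log units; within the scatter) leaves (1,3-thiazol-2-yl)carbonyl level with (3-methyl-2-oxoimidazolidin-1-yl)methyl. An aromatic heterocycle here therefore need not raise the number, and the two such groups shown stand far apart, with an 18-fold lower number from compound 3 to compound 4 (1.25 log units; beyond the scatter). Both a 4.2-fold lower number from compound 1 to compound 2 (0.62 log units; beyond the scatter) and a 3.7-fold lower number from compound 1 to compound 4 (0.57 log units; beyond the scatter) run in the same direction. Nothing given here accounts for these numbers.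

The step to compound 4 changes the linker and the ring together, so the compounds shown leave open which of the two carries the result, and a (1,3-thiazol-2-yl)methyl group would separate them. Also open, going by these compounds, is how a carboxylic acid at this position would read.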